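The source may hold more compounds than are shown below. What is called first, only, known or untested is meant among the compounds shown, and "the series" means these compounds.

Measured so far:
Compound 1 `CC1CCCCC1N(CCCCCCN1C[C@H](O)[C@@H](O)[C@H](O)[C@H]1CO)C(=O)C(C)(C)C`. In an ADME assay on MDBK cells (Bos taurus) for cytotoxicity, read by MTT assay (on this read-out lower numbers stand for higher toxicity in this test and higher numbers for lower toxicity in this test), compound 1 gives > 500000 nM, which is a limit of the assay.
Compound 2 `CC(C)(C)C(=O)N(CCCCCCN1C[C@H](O)[C@@H](O)[C@H](O)[C@H]1CO)C1CC1`. In this assay compound 2 gives > 500000 nM, which is a limit of the assay.
Compound 3 `CC(C)(C)C(=O)N(CCCCCCN1C[C@H](O)[C@@H](O)[C@H](O)[C@H]1CO)C1CCC1`. In this assay compound 3 gives > 500000 nM, which is a limit of the assay.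

Compound 3 thus stands only at a limit in this assay, and the two other values shown are limits as well, all three resting at the limit of > 500000 nM in this assay, at which 3 of the 3 values shown sit. The steps a step that the two limits leave unreadable from compound 1 to compound 2, a step that the two limits leave unreadable from compound 1 to compound 3 and a step that the two limits leave unreadable from compound 2 to compound 3 are unreadable in size and direction due to the limit of > 500000 nM in this assay, at which 3 of the 3 values shown sit.

Compound 4 `CC(C)(C)C(=O)N(CCCCCCN1C[C@H](O)[C@@H](O)[C@H](O)[C@H]1CO)C1CCCCCCC1` differs from compound 3 by cyclooctyl in place of cyclobutyl on an amide-type nitrogen. The measured steps that bear on this change are the exchanges between ring sizes on the same amide-type nitrogen, and none of them yields a readable size, so no direction can be taken from them for this assay. Compound 4 is expected to sit at or near the same limit, with the step of an at least 1.2-fold lower number from compound 3 to compound 4 (0.09 log units; that floor lies within the scatter) expected to remain within what the limit can show. The estimate for compound 4 in this assay is 400000 nM, with a range from 100000 nM to 1000000 nM, and a substantial chance that only a limit is reported again.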

Compound 4, half-maximal cytotoxic concentration: 270000 nM
Beside the measured number, compound 4's estimate is 1.5-fold (0.17 log units) above it; the range from low to high includes it.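

For the compounds shown here, compound 4, with cyclooctyl on the amide-type nitrogen, is the only one of the four compounds to give a measured number rather than a limit in this assay, which makes the ring on this nitrogen readable for the first time, though only from one side: an at least 1.8-fold lower number from compound 3 to compound 4 (0.26 log units; that floor lies within the scatter), an at least 1.8-fold lower number from compound 2 to compound 4 (0.26 log units; that floor lies within the scatter) and an at least 1.8-fold lower number from compound 1 to compound 4 (0.26 log units; that floor lies within the scatter). Each of these three steps is only a floor, and with that floor inside the scatter, they do not yet establish a real difference between cyclooctyl and the smaller rings. The steps among compound 1, compound 2 and compound 3 still cannot be read in size or direction, because those compounds rest at one shared limit: the limit of > 500000 nM in this assay, at which 3 of the 4 values shown sit.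

On these data alone, it remains open whether cytotoxicity in this assay tracks ring size on this nitrogen or whether cyclooctyl is a special case, and an unsubstituted cyclohexyl or a cycloheptyl in the same place would bear on that. Also open, as far as these compounds go, is how a polar group such as an amine or a carboxylic acid on the cyclooctyl ring, or a phenyl in its place, would read here.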